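The source may hold more compounds than are shown below. What is called first, only, known or untested is meant among the compounds shown, and "the series" means these compounds.

Measured so far in a functional assay on K562 cells (Homo sapiens) for cytotoxicity, read by trypan blue exclusion, with a stated time of 96 h; on this read-out lower numbers stand for stronger inhibition and higher numbers for weaker inhibition:
compound 1 `COC(=O)CNc1cc(CS(=O)(=O)/C=C/c2c(OC)cc(OC)cc2OC)ccc1OC`: 100 nM
compound 2 `COC(=O)C(Nc1cc(CS(=O)(=O)/C=C/c2c(OC)cc(OC)cc2OC)ccc1OC)c1ccc(F)cc1`: 800 nM
compound 3 `COC(=O)C(Nc1cc(CS(=O)(=O)/C=C/c2c(OC)cc(OC)cc2OC)ccc1OC)c1ccc(OC)cc1`: 150 nM

Compound 2 gives the highest number of the three in this assay; its nearest neighbour is compound 3 at a 5.3-fold lower number from compound 2 to compound 3 (0.73 log units; beyond the scatter), and the step from compound 1 is an 8.0-fold higher number from compound 1 to compound 2 (0.90 log units; beyond the scatter). Compound 4 `COc1cc(OC)c(/C=C/S(=O)(=O)Cc2ccc(OC)c(NC(C(=O)O)c3ccc(Cl)cc3)c2)c(OC)c1` is not yet measured. It differs from compound 2 as follows: carboxy(4-chlorophenyl)methyl in place of (4-fluorophenyl)(methoxycarbonyl)methyl on a nitrogen on an aromatic ring.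

Two things change at once. The step that bears most directly on the aromatic part is a 5.3-fold lower number from compound 2 to compound 3 (0.73 log units; beyond the scatter), which shows that exchanging the fluoro on the aromatic carbon for another group can move the number well beyond the scatter. Going by the values given here, no measured step speaks to the exchange of the methoxycarbonyl for the carboxy group, so that part of the change is unanchored. Among the compounds with values here, a chloro is not a methoxy, and there is no pair in hand to say whether it would follow the same direction. On balance no step beyond the scatter is expected, with a wide range on either side. For compound 4 the estimate is 1000 nM, between 250 nM and 4000 nM, which corresponds to an expected step of a 1.3-fold higher number from compound 2 to compound 4 (0.10 log units; within the scatter).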

Compound 4, half-maximal inhibitory concentration: 250 nM
Compound 4: the middle estimate sits 4.0-fold (0.60 log units) above what was measured; the measured number falls inside the stated range.
By their numbers in this assay, from the lowest: compounds 1, 3 and 4 (each within the scatter of the next, the first and the last beyond it); then compound 2.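

Among the groups on a nitrogen on an aromatic ring in this assay, carboxy(4-chlorophenyl)methyl is the first to carry a carboxy in place of a methoxycarbonyl, and in place of (methoxycarbonyl)methyl it gives a 2.5-fold higher number from compound 1 to compound 4 (0.40 log units; beyond the scatter) and so costs only a modest step. In place of (4-fluorophenyl)(methoxycarbonyl)methyl it gives a 3.2-fold lower number from compound 2 to compound 4 (0.51 log units; beyond the scatter) and so shows that a methoxycarbonyl is not required at this place. No measurement on hand accounts for either step.

As far as these compounds go, how much of the gain belongs to the carboxy and how much to the chloro stays open, and a 4-chlorophenyl with a methoxycarbonyl or a 4-fluorophenyl with a carboxy would separate the two. From the compounds shown here alone, whether a primary amide in place of the carboxy, or an unsubstituted phenyl, would hold the number here is also open.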